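Pyrrolidin-1-yl replaces 2-aminoethyl: what to expect

A few compounds are considered here, and "the series" means these few. Any claim that something is new, unique, unknown or untested is made for them only; others in the source may bear on it.

- Compound 1 `CC(C)=CCC/C(C)=C\CCC(C)=CCNCCCN` gives 32100 nM
- Compound 2 `CC(C)=CCC/C(C)=C\CCC(C)=CCNCCCCCN` gives 38400 nM

In a toxicity assay on CHO cells (Cricetulus griseus) for cytotoxicity, read by WST assay, with a stated time of 24 h (a lower number here means a stronger inhibitor, a higher number a weaker inhibitor), only these two compounds have been measured so far, and compound 2 cannot be told apart from compound 1 on these numbers. Compound 3 `CC(C)=CCC/C(C)=C\CCC(C)=CCNCCCN1CCCC1` has not been measured yet. It differs from compound 2 as follows: pyrrolidin-1-yl in place of 2-aminoethyl on a saturated chain carbon, three bonds along the chain from an amine nitrogen. Within the data shown here, one measured step bears on this change, and it sits at the same place on the chain: 2-aminoethyl in place of amino gave a 1.2-fold higher number from compound 1 to compound 2 (0.08 log units; within the scatter). Among the measured compounds shown here, no measured compound carries a ring there, so this evidence is thin. A step beyond the scatter in this assay is therefore not expected, in either direction. The estimated change is a 1.1-fold lower number from compound 2 to compound 3 (0.04 log units; within the scatter). Compound 3 is expected at 35000 nM, with an estimated range of 17000 nM to 70000 nM.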

Compound 3, half-maximal inhibitory concentration: 85300 nM
For compound 3 the middle estimate is 2.4-fold (0.39 log units) below the measured one; measured number outside the range, above it.
By their numbers in this assay, from the lowest: compounds 1 and 2 (each within the scatter of the next); then compound 3.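

At this place, on a saturated chain carbon, three bonds along the chain from an amine nitrogen, the earlier change from amino to 2-aminoethyl stayed within the scatter in this assay (a 1.2-fold higher number from compound 1 to compound 2 (0.08 log units; within the scatter)). Pyrrolidin-1-yl is the first group here to move the number beyond the scatter, and the shift is modest and the same way from both open-chain compounds (a 2.2-fold higher number from compound 2 to compound 3 (0.35 log units; beyond the scatter); a 2.7-fold higher number from compound 1 to compound 3 (0.42 log units; beyond the scatter)), so the end of the chain is not indifferent to every change in this test of harm to cells. Nothing measured here explains this step.

The ring and the loss of the hydrogen-bond donor arrive together in pyrrolidin-1-yl, so the compounds shown cannot separate them. A diethylamino group would keep the donor count of pyrrolidin-1-yl without a ring, and piperidin-1-yl would show whether ring size matters.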